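Adding a nitrobenzyl thioether to a weak gastric-cancer cell inhibitor

The source may hold more compounds than are shown below. What is called first, only, known or untested is meant among the compounds shown, and "the series" means these compounds.

Compound 1 `Cc1cc(N2CC[C@@H](C)[C@@H](N(C)c3ncnc4[nH]ccc34)C2)n2ncnc2n1`: 11300 nM
Compound 2 `Cc1cc(N2CC[C@@H](C)[C@@H](N(C)c3ncnc4[nH]ccc34)C2)n2nc(SCc3ccccc3Br)nc2n1`: 21300 nM
Compound 3 `Cc1cc(N2CC[C@@H](C)[C@@H](N(C)c3ncnc4[nH]ccc34)C2)n2nc(SCc3csc4ccc(Cl)cc34)nc2n1`: > 100000 nM

In a functional assay on HGC-27 cells (Homo sapiens) for inhibition, read by MTT assay, with a stated time of 72 h (a higher number here means a weaker inhibitor, a lower number a stronger inhibitor), compound 1 gives 11300 nM, and compound 2 sits within the scatter of it. Compound 3 reaches only a limit of the assay, > 100000 nM. Compound 4 `Cc1cc(N2CC[C@@H](C)[C@@H](N(C)c3ncnc4[nH]ccc34)C2)n2nc(SCc3ccc([N+](=O)[O-])cc3)nc2n1` carries the change ((4-nitrobenzyl)sulfanyl in place of hydrogen on an aromatic carbon). The two measured steps at the same place are a 1.9-fold higher number from compound 1 to compound 2 (0.28 log units; within the scatter) and an at least 8.8-fold higher number from compound 1 to compound 3 (0.94 log units; beyond the scatter); the single-ring group, as in compound 2, cost little, while the fused group cost more, as an at least 4.6-fold higher number from compound 2 to compound 3 (0.67 log units; beyond the scatter) shows. A nitrobenzyl group is a single ring, so a small loss is expected: a 2.2-fold higher number from compound 1 to compound 4 (0.34 log units; beyond the scatter). The expected value for compound 4 is 25000 nM, between 10000 nM and 70000 nM.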

Compound 4, half-maximal inhibitory concentration: 29400 nM
Beside the measured number, compound 4's estimate is 1.2-fold (0.07 log units) below it; measured number inside the range.
By their numbers in this assay, from the lowest: compounds 1, 2 and 4 (each within the scatter of the next, the first and the last beyond it). At a limit, above all of these: compound 3.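

In this assay, a second single-ring group at this carbon, (4-nitrobenzyl)sulfanyl, also costs little, though this loss is modest rather than within the scatter: a 2.6-fold higher number from compound 1 to compound 4 (0.42 log units; beyond the scatter). The nitro and bromo single-ring groups cannot be told apart: a 1.4-fold higher number from compound 2 to compound 4 (0.14 log units; within the scatter). The fused group of compound 3 stays clearly apart from the nitrobenzyl group, an at least 3.4-fold lower number from compound 3 to compound 4 (0.53 log units; beyond the scatter), and that step rests on a limit: the limit of > 100000 nM in this assay, at which 1 of the 4 values shown sits.

As far as these compounds go, what an amine or a carboxylic acid would do at this carbon stays open, as does whether any group here can give a clearly lower number than compound 1.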